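Pyridin-2-yl ether in place of trifluoromethoxyphenyl: cytotoxicity notes

A few compounds are considered here, and "the series" means these few. Any claim that something is new, unique, unknown or untested is made for them only; others in the source may bear on it.

Working notes on a small set of ether-linked compounds built on one shared core. Among the compounds with values here, compound 2 `Cc1cn(C2CCN(Cc3cccc(Oc4cccc(OC(F)(F)F)c4)c3)CC2)c(=O)[nH]c1=O` gives 5260 nM in an ADME assay on MRC5 cells (Homo sapiens) for cytotoxicity, read by fluorescence and resazurin assay, with a stated time of 3 days (on this read-out lower numbers stand for stronger inhibition and higher numbers for weaker inhibition), and this is the only single number on the read-out in the set. Compound 1 `Cc1cn(C2CCN(Cc3cc(Oc4ccccc4)ccn3)CC2)c(=O)[nH]c1=O` returns > 64000 nM in this assay, which is a limit of the assay and not a number; the relevant line is the limit of > 64000 nM in this assay, at which 1 of the 3 values shown sits. Compound 3 `Cc1cn(C2CCN(Cc3cccc(Oc4ccc(O)cc4)n3)CC2)c(=O)[nH]c1=O` is recorded as "not determined" (no result reported) in this assay, so no result is reported for it. Within the data shown here, with one number, one limit and one blank, no step between measured compounds can be drawn, so compound 2 stands alone as the reference point.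

Compound 4 `Cc1cn(C2CCN(Cc3cccc(Oc4ccccn4)c3)CC2)c(=O)[nH]c1=O` differs from compound 2 in a single place: pyridin-2-yl in place of 3-(trifluoromethoxy)phenyl on an oxygen on an aromatic ring. Among the measured compounds shown here, no measured pair in the set shares this change, so its size is a matter of expectation only. The expectation for this assay is a move toward weaker inhibition, larger than the usual scatter, with a real chance that only a limit is returned. Compound 4 is expected to give about 30000 nM in this assay, with a likely range from 8000 nM to 90000 nM. This estimate corresponds to a step of a 5.7-fold higher number from compound 2 to compound 4 (0.76 log units; beyond the scatter).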

Compound 4, half-maximal inhibitory concentration: > 64000 nM
Compound 4 was reported as a limit (the forecaster's own chance of this, stated with the estimate: 45%); at least 2.1-fold (0.32 log units) between middle value and limit.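

On this assay, the change on an oxygen on an aromatic ring now has a first measured size: pyridin-2-yl in place of 3-(trifluoromethoxy)phenyl gives an at least 12-fold higher number from compound 2 to compound 4 (1.08 log units; beyond the scatter). Compound 4 gives > 64000 nM, which is a limit of the assay and not a number, so the step has a lower bound only and its full size cannot be read. This single change is enough to take the series from the only single number on the read-out to the top of the measurable range: the limit of > 64000 nM in this assay, at which 2 of the 4 values shown sit.

The step swaps the carbon-only ring for one with a ring nitrogen and removes the trifluoromethoxy group in the same move, so the compounds shown cannot say which of the two carries the shift, and a plain phenyl on this oxygen on the core of compound 2 would be needed to separate them. On these data alone, it also stays open how a pyridin-2-yl carrying an amine or a carboxylic acid would read on this assay, and whether any such ring returns a single number rather than a limit.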